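Amide substitution on the shared core and paw edema inhibition

A few compounds are considered here, and "the series" means these few. Any claim that something is new, unique, unknown or untested is made for them only; others in the source may bear on it.

Of the compounds shown here, two carrying the same core have been measured in a functional assay on the whole organism (strain Wistar) for inhibition, with Rattus norvegicus as the target, read by paw edema, with stated times of 30 min and 2 h, at a dose of 20 mg/kg; on this read-out lower numbers stand for less inhibition and higher numbers for more inhibition at the one dose given (going by the name of the read-out). Compound 1 `CCOC(=O)C1=C(C)NC(C)=C(C(=O)OCC)C1c1ccc(OCC(=O)Nc2c(C)cccc2C)cc1` gives 47.8% in this assay. Compound 2 `CCOC(=O)C1=C(C)NC(C)=C(C(=O)OCC)C1c1ccc(OCC(=O)NNC(=O)CCC(=O)O)cc1` gives 57.8% in this assay. Within the data shown here, compound 1 thus stands as one of only two numbers, and its nearest neighbour compound 2 lies within the usual scatter of it: a number 10 percentage points higher from compound 1 to compound 2 (within the scatter).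

Compound 3 `CCOC(=O)C1=C(C)NC(C)=C(C(=O)OCC)C1c1ccc(OCC(=O)NN2C(=O)c3ccccc3C2=O)cc1` is not yet measured. It differs from compound 1 at the amide-type nitrogen whose other neighbour is a carbonyl carbon: a group of 11 heavy atoms (8 carbon, 1 nitrogen, 2 oxygen; one five-membered non-aromatic ring with 1 hetero atom, one six-membered aromatic ring of carbon only) in place of a group of 8 heavy atoms (8 carbon; one six-membered aromatic ring of carbon only), on an amide-type nitrogen

Among the measured compounds shown here, the only measured step that bears on this change is the one at the same amide-type nitrogen, from compound 1 to compound 2, where a different group replaced the 2,6-dimethylphenyl and the read-out moved by a size within the scatter. On that single precedent, the step from compound 1 to compound 3 is expected to be a number 4.2 percentage points higher from compound 1 to compound 3 (within the scatter), that is, nothing beyond the scatter in either direction. Compound 3 is therefore estimated at 52% in this assay, with a range from 38% to 66%.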

Compound 3, a percentage reported as inhibition, in the whole organism at one dose (the size of the read-out at that dose, not a potency): 57.2%
Beside the measured number, compound 3's estimate is 5.2 percentage points below it; the range from low to high includes it.
By their numbers in this assay, from the lowest: compounds 1, 3 and 2 (each within the scatter of the next).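

At the amide-type nitrogen whose other neighbour is a carbonyl carbon, replacing 2,6-dimethylphenyl with a group of 11 heavy atoms, carrying a five-membered non-aromatic ring and a six-membered aromatic ring, gives in this assay a number 9.4 percentage points higher from compound 1 to compound 3 (within the scatter). Set against the ring-free group of 8 heavy atoms on the same nitrogen, the same group gives a number 0.6 percentage points lower from compound 2 to compound 3 (within the scatter), so three groups that differ in size, ring content and hydrogen-bond acceptor count now stand within the scatter of one another, and the read-out does not separate them at this one dose. No measurement is available that would explain this result at this position.

The compounds shown leave open whether any group on this nitrogen can move the read-out beyond the scatter, for instance a bare amino group or a small methyl group, both far smaller than the three groups seen so far. They also leave open whether these three groups would separate at other doses, since a single dose gives the size of the read-out and not a potency.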